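The source may hold more compounds than are shown below. What is called first, only, known or untested is meant among the compounds shown, and "the series" means these compounds.

Measured in a functional assay on MCF7 cells (Homo sapiens) for cytotoxicity, read by ELISA, with a stated time of 4 days; a lower number here means a stronger inhibitor, a higher number a weaker inhibitor:
compound 1 `Cc1ccsc1-c1cc(-c2ccco2)cc(-c2ccccc2Cl)n1`: 14200 nM
compound 2 `Cc1ccsc1-c1cc(-c2ccoc2)cc(-c2ccco2)n1`: 18300 nM
compound 3 `Cc1ccc(-c2cc(-c3ccoc3)cc(-c3ccc(Cl)s3)n2)o1`: 1900 nM

Of these three, compound 3 gives the lowest number, and compound 1 and compound 2 both lie above it by more than the scatter. Compound 4 `Clc1ccc(-c2cc(-c3ccoc3)cc(-c3ccc(Cl)s3)n2)cc1` carries 4-chlorophenyl in place of 5-methylfuran-2-yl on an aromatic carbon, next to the ring nitrogen (4-chlorophenyl in place of 5-methylfuran-2-yl on an aromatic carbon). Within the data shown here, no pair of measured compounds shows this change alone, so the expectation starts from compound 3 at 1900 nM and foresees no step beyond the scatter in this assay, with any drift upward. The estimated change is a 1.6-fold higher number from compound 3 to compound 4 (0.20 log units; within the scatter). Compound 4 is expected at 3000 nM, within an estimated range from 900 nM to 10000 nM.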

Compound 4, half-maximal inhibitory concentration: 2600 nM
For compound 4 the middle estimate is 1.2-fold (0.06 log units) above the measured one, and the stated range covers the measured number.
By their numbers in this assay, from the lowest: compounds 3 and 4 (each within the scatter of the next); then compounds 1 and 2 (each within the scatter of the next).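

In this assay, the place next to the ring nitrogen takes 4-chlorophenyl in place of 5-methylfuran-2-yl with a 1.4-fold higher number from compound 3 to compound 4 (0.14 log units; within the scatter), so at this place, in this pair, a six-membered aromatic ring of carbon only reads the same as a five-membered aromatic ring with 1 hetero atom. No measurement bears on why the two compounds read alike. Going by these compounds, what stays open is whether an amine or a carboxylic acid at this place would read alike. Also open, on these data alone, is whether 4-chlorophenyl would give the same reading with the furan-3-yl or the 5-chlorothiophen-2-yl group replaced.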